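Working notes: bromo in place of ethynyl

The source may report more compounds than this note shows. Statements on the series, on what has been measured and on what is new or still open speak of the compounds shown alone.

Measured in a functional assay on RCC4 cells (Homo sapiens) for inhibition, read by XTT assay, with a stated time of 4 days; on this read-out higher numbers stand for weaker inhibition and lower numbers for stronger inhibition:
compound 1 `Cc1cccc(Nc2nc(-c3ccnc(-c4cncnc4)c3)cs2)c1`: 26400 nM; 26900 nM (2 entries)
compound 2 `Cc1cccc(Nc2nc(-c3ccnc(-c4ccncc4)c3)cs2)c1`: 28900 nM; 29500 nM (2 entries)
compound 3 `C#Cc1cc(-c2csc(Nc3cccc(C)c3)n2)ccn1`: 18200 nM

The repeat entries of compound 1 the several entries of compound 1 in this assay, 26400 nM; 26900 nM (2 entries) and of compound 2 the several entries of compound 2 in this assay, 28900 nM; 29500 nM (2 entries) agree closely with each other. For compound 3 only one number is shown in this assay; two further entries carry no single number. Compound 3 and compounds 1 and 2 lie within the scatter of each other, so no order among them is claimed.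

Compound 4 `Cc1cccc(Nc2nc(-c3ccnc(Br)c3)cs2)c1` differs from compound 3 by bromo in place of ethynyl on an aromatic carbon. Within the data shown here, no measured step of this kind is available. The step from compound 3 to compound 4 is expected to stay within the scatter, a 1.2-fold higher number from compound 3 to compound 4 (0.08 log units; within the scatter). Compound 4 is therefore estimated at 22000 nM, with a range from 9000 nM to 55000 nM.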

Compound 4, half-maximal inhibitory concentration: 2040 nM
Compound 4: the middle estimate sits 11-fold (1.03 log units) above what was measured, outside the stated range (below it).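

In this assay, bromo in place of ethynyl on the aromatic carbon next to the ring nitrogen gives an 8.9-fold lower number from compound 3 to compound 4 (0.95 log units; beyond the scatter). Compound 1, compound 2 and compound 3 lie within the scatter of each other, so this is the only sign among the compounds shown that the group at this position can shift the read-out. Nothing measured here accounts for the step. Whether the shift is particular to bromo stays open, as the compounds shown include neither chloro nor an amine at this position.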